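A few compounds are considered here, and "the series" means these few. Any claim that something is new, unique, unknown or untested is made for them only; others in the source may bear on it.

Working notes on the series in a functional assay on HL-60 cells (Homo sapiens) for inhibition, read by MTT assay, with a stated time of 72 h, tested at 50 uM; a lower number here means less inhibition of growth, a higher number more inhibition of growth at the concentration tested. Compound 1 (`C=CCc1ccc(OCc2cn(-c3cc(OC)c(OC)c(OC)c3)nn2)c(O)c1`) gives 41.4%, compound 2 (`C=CCc1ccc(OCc2cn(-c3ccccc3Cl)nn2)c(O)c1`) gives 43.2% and compound 3 (`C#CCOc1ccc(CC=C)cc1O`) gives 34.2%. The values of compound 1 and compound 3 both lie within the scatter of compound 2, so the three form no ranking. Compound 4 (`C=CCc1ccc(OCc2cn(-c3ccc(Br)cc3)nn2)c(O)c1`) has 4-bromophenyl in place of 2-chlorophenyl on an aromatic nitrogen. For the measured compounds named here, no single-place step has been measured, so the expectation rests on these values alone. Compound 1, with another group on that nitrogen, stays within the scatter of compound 2. The expected step is a number 1.8 percentage points higher from compound 2 to compound 4 (within the scatter), none beyond the scatter in this assay. For compound 4 the estimated value is 45%, with an expected range of 33% to 58%.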

Compound 4, percent growth inhibition at one concentration: 25.6%
Compound 4: middle estimate off by 19.4 percentage points, on the high side; the whole stated range lies above it.
By their numbers in this assay, from the lowest: compounds 4, 3, 1 and 2 (each within the scatter of the next, the first and the last beyond it).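

In this assay, 4-bromophenyl in place of 2-chlorophenyl on the aromatic nitrogen gives a number 17.6 percentage points lower from compound 2 to compound 4 (beyond the scatter), so this position responds to the group it carries, which the pair compound 1 and compound 2 did not show. The two groups match in every computed count, yet the halogen and its place on the phenyl ring change together. Nothing measured on these compounds bears on the origin of this step.

From the compounds shown here alone, whether the step follows the halogen or its place on the phenyl ring stays open. Also open, going by these compounds, is how an amine or a carboxylic acid on that phenyl ring would read.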